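Naphthalen-1-yl to 2,4-Difluorophenyl: What Compound 4 Should Show

A few compounds are considered here, and "the series" means these few. Any claim that something is new, unique, unknown or untested is made for them only; others in the source may bear on it.

Three compounds share one core and differ only in the group carried on an amine nitrogen in a ring. Compound 1 `Nc1scc(CN2CCN(c3ccc(Cl)cc3Cl)CC2)c1C(=O)c1ccc(Cl)cc1` gives 2% in a functional assay on CHO cells with adenosine receptor A1 (Homo sapiens) as the target, read by cAMP accumulation and immunoassay, with a stated time of 6 min, tested at 0.01 uM; a lower number here means a stronger effect, a higher number a weaker effect of the compound at the concentration tested. Compound 2 `Nc1scc(CN2CCN(C3CCCCCC3)CC2)c1C(=O)c1ccc(Cl)cc1` gives 2.9% in this assay, and compound 3 `Nc1scc(CN2CCN(c3cccc4ccccc34)CC2)c1C(=O)c1ccc(Cl)cc1` gives 8.7% in this assay. Compound 3 holds the highest of the three numbers; its nearest neighbour is compound 2 and its furthest is compound 1, yet both gaps, a number 5.8 percentage points higher from compound 2 to compound 3 (within the scatter) and a number 6.7 percentage points higher from compound 1 to compound 3 (within the scatter), sit inside the usual scatter, so the three compounds cannot be told apart on these data.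

Compound 4 `Nc1scc(CN2CCN(c3ccc(F)cc3F)CC2)c1C(=O)c1ccc(Cl)cc1` has not yet been measured. It differs from compound 3 by 2,4-difluorophenyl in place of naphthalen-1-yl on an amine nitrogen in a ring. The step that bears most on this change is a number 6.7 percentage points higher from compound 1 to compound 3 (within the scatter), since the present change runs in the opposite direction, back from naphthalen-1-yl to a 2,4-dihalogenated phenyl, now with fluorine in place of chlorine. The step of a number 5.8 percentage points higher from compound 2 to compound 3 (within the scatter) was of similar size. Neither gives reason to expect a shift beyond the scatter.

Compound 4 is therefore expected to give 3% in this assay, with a range from 0% to 10%. The expected step of a number 5.7 percentage points lower from compound 3 to compound 4 (within the scatter) is estimated to be small, downward, and within the scatter.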

Compound 4, a percentage reported as activity, at one concentration (the size of the read-out at that concentration, not a potency): 0%
Compound 4: the middle estimate sits 3 percentage points above what was measured; low and high end bracket the measured number.
By their numbers in this assay, from the lowest: compounds 4, 1, 2 and 3 (each within the scatter of the next).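

Putting 2,4-difluorophenyl in place of naphthalen-1-yl on the amine nitrogen replaces two aromatic rings with one, yet in this assay the step is a number 8.7 percentage points lower from compound 3 to compound 4 (within the scatter) and so gives no sign of a real difference. The comparisons with the other two groups read the same way, with a number 2.9 percentage points lower from compound 2 to compound 4 (within the scatter) and a number 2 percentage points lower from compound 1 to compound 4 (within the scatter) both printed for this position. A fluorine-bearing phenyl therefore joins a chlorine-bearing phenyl, cycloheptyl and naphthalen-1-yl in one set of groups that these data cannot tell apart, and nothing measured here offers an explanation for that.

Going by these compounds, all four groups are carbon rings, with or without halogen, so it remains open whether a different kind of group on this nitrogen, such as a carboxylic acid or a chain ending in an amine, would give a step beyond the scatter. The read-out also comes from one concentration and is not a potency, which leaves open whether the four compounds would separate at other concentrations.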